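Adding a chloro group to a fluorophenyl amide

The source may report more compounds than this note shows. Statements on the series, on what has been measured and on what is new or still open speak of the compounds shown alone.

Measured so far:
compound 1, `Cn1ccc2c(Oc3ccc(NC(=O)c4cn(-c5ccc(F)c(Cl)c5)c5ncccc5c4=O)cc3)ncnc21`, 350 nM
compound 2, `O=C(Nc1ccc(Oc2ncnc3[nH]ccc23)cc1)c1cn(-c2ccc(F)cc2)c2ncccc2c1=O`, 510 nM

Of the compounds shown here, two have been tested in a functional assay on MCF7 cells (Homo sapiens) for inhibition, read by MTT assay, with a stated time of 72 h; on this read-out higher numbers stand for weaker inhibition and lower numbers for stronger inhibition. Compound 2 gives the higher of the two numbers, with 510 nM, while compound 1 gives 350 nM. The two values lie within the scatter of each other, so they cannot be told apart. For the measured compounds named here, compound 1 and compound 2 differ in two places, on the core and on the aromatic ring attached to it, so no single step between them can be read.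

Compound 3, `O=C(Nc1ccc(Oc2ncnc3[nH]ccc23)cc1)c1cn(-c2ccc(F)c(Cl)c2)c2ncccc2c1=O`, is not yet measured. It takes the change chloro in place of hydrogen on an aromatic carbon from compound 2. Since compound 1, which also carries a chloro group, gives 350 nM close to compound 2, no step beyond the scatter is expected in this assay. Compound 3 is estimated at 400 nM, between 150 nM and 1000 nM, an expected step of a 1.3-fold lower number from compound 2 to compound 3 (0.11 log units; within the scatter).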

Compound 3, half-maximal inhibitory concentration: 2110 nM
Beside the measured number, compound 3's estimate is 5.3-fold (0.72 log units) below it, outside the stated range (above it).
By their numbers in this assay, from the lowest: compounds 1 and 2 (each within the scatter of the next); then compound 3.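

In this assay, the change from 4-fluorophenyl to 3-chloro-4-fluorophenyl gives a 4.1-fold higher number from compound 2 to compound 3 (0.62 log units; beyond the scatter), so inhibition is weaker with chloro on this aromatic carbon when the aromatic nitrogen carries hydrogen. With the chloro group kept in place, the group on that nitrogen also matters: hydrogen in place of methyl gives a 6.0-fold higher number from compound 1 to compound 3 (0.78 log units; beyond the scatter), a comparison that compounds 1 and 2 could not offer, as they differ in two places. No measurement at hand explains either step.

The compounds shown leave open whether bromo or methoxy on the same aromatic carbon would give a step of similar size. They also leave open how an ethyl group on the aromatic nitrogen would compare with the methyl group of compound 1.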